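Swapping a carbamate ester for a cyclopentyl amide

The source may report more compounds than this note shows. Statements on the series, on what has been measured and on what is new or still open speak of the compounds shown alone.

Compound 2, with the structure `CCC1(OC(=O)N2CCC(Oc3ncnc(Oc4ccc(S(C)(=O)=O)nc4C)c3F)CC2)CC1`, was tested in a functional assay on isolated protein for inhibition of Glucose-dependent insulinotropic receptor (Rattus norvegicus), read by HTRF and cAMP accumulation (on this read-out higher numbers stand for larger maximal responses and lower numbers for smaller maximal responses), where compound 2 gives 83%. For the measured compounds named here, the only other compound measured, compound 1 with the structure `Cc1nc(S(C)(=O)=O)ccc1Oc1ncnc(OC2CCN(C(=O)O[C@H](C)CF)CC2)c1F`, gives 79% in this assay, so the two values lie within the usual scatter of each other and neither can be set above the other. Going by the values given here, the step between them, a number 4 percentage points higher from compound 1 to compound 2 (within the scatter), is the single comparison available.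

Compound 3, with the structure `Cc1nc(S(C)(=O)=O)ccc1Oc1ncnc(OC2CCN(C(=O)C3CCCC3)CC2)c1F`, has not yet been measured. It differs from compound 2 in one place: a group of 5 heavy atoms (5 carbon; one five-membered non-aromatic ring of carbon only) in place of a group of 6 heavy atoms (5 carbon, 1 oxygen; one three-membered non-aromatic ring of carbon only), on a carbonyl carbon. This alters the same part of the molecule that was varied between compound 1 and compound 2, where that variation gave no shift beyond the scatter. Among the compounds with values here, with only this one step to go on, the expectation for compound 3 in this assay is a maximal response close to that of compound 2, a step of a number 3 percentage points lower from compound 2 to compound 3 (within the scatter) that stays within the scatter. The estimate for compound 3 is 80%, with a range from 68% to 92%.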

Compound 3, largest response reached (reported as efficacy), in percent of the reference or control that the assay uses: 83%
Estimate against measurement, compound 3: 3 percentage points below, within the range that was stated.
By their numbers in this assay, from the lowest: compounds 1, 2 and 3 (each within the scatter of the next).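

In this assay, replacing the oxygen-bearing group with cyclopentyl on the carbonyl carbon gives no change at the digits printed from compound 2 to compound 3 (within the scatter), while the comparison with the fluorinated group gives a number 4 percentage points higher from compound 1 to compound 3 (within the scatter). This extends the earlier comparison, in which both groups carried an oxygen on the carbonyl carbon: cyclopentyl has no oxygen and no hydrogen-bond acceptor, yet the maximal response of compound 3 cannot be told apart from those of compound 1 and compound 2, so among these compounds that oxygen is not needed for a response of this size. No supporting data are available to explain why these different groups read alike.

From the compounds shown here alone, all three groups on the carbonyl carbon are uncharged, so it remains open whether a group carrying an amine or a carboxylic acid, or a longer chain such as n-hexyl, would keep the maximal response within the scatter of these values. These numbers also describe only the largest response reached, leaving open how much of each compound is needed to reach it.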